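Furan-3-yl in Place of Furan-2-yl: An Expected Outcome

A few compounds are considered here, and "the series" means these few. Any claim that something is new, unique, unknown or untested is made for them only; others in the source may bear on it.

Compound 1 `COc1ccc(CNC(=O)/C(C#N)=C/c2ccco2)cc1` gives 27000 nM in a functional assay on MCF7 cells (Homo sapiens) for inhibition, read by MTT assay, with a stated time of 72 h; a lower number here means a stronger inhibitor of growth, a higher number a weaker inhibitor of growth.
Compound 2 `N#C/C(=C\c1ccco1)C(=O)NCc1ccc(Cl)c(Cl)c1` gives 20000 nM in this assay.
Compound 3 `COc1ccc(CNC(=O)/C(C#N)=C/c2ccc(-c3ccccc3)o2)cc1` gives 3000 nM in this assay.

Among the three measured compounds, compound 1 has the highest number in this assay. Its nearest neighbour is compound 2, whose value lies within the scatter of that of compound 1, so the two cannot be ordered. Among the measured compounds shown here, the only measured step that goes beyond the scatter is a 9.0-fold lower number from compound 1 to compound 3 (0.95 log units; beyond the scatter), which concerns a phenyl in place of hydrogen on an aromatic carbon of the furan ring.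

Compound 4 `COc1ccc(CNC(=O)/C(C#N)=C/c2ccoc2)cc1` differs from compound 1 in another way: furan-3-yl in place of furan-2-yl on a double-bonded chain carbon bound to a double-bonded chain carbon. The same atoms are present, joined differently. For the measured compounds named here, no measured step touches the attachment point of the furan ring, so nothing in the data bears directly on this change; the step from compound 1 to compound 3 concerns a substituent on the ring, not the ring's point of attachment, and gives no guidance here.

Going by the values given here, with no precedent in the measured compounds, the expected step in this assay, a 1.1-fold higher number from compound 1 to compound 4 (0.05 log units; within the scatter), is one that stays within the scatter. Compound 4 is therefore estimated at 30000 nM, with a range from 12000 nM to 75000 nM.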

Compound 4, concentration for 50% growth inhibition: 7000 nM
Estimate against measurement, compound 4: 4.3-fold (0.63 log units) above; measured number below the stated range.
By their numbers in this assay, from the lowest: compound 3; then compound 4; then compounds 2 and 1 (each within the scatter of the next).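

In this assay the attachment point of the furan ring proves to count on its own, with a 3.9-fold lower number from compound 1 to compound 4 (0.59 log units; beyond the scatter), although the leaving and entering groups have the same heavy atoms, the same ring type and the same counts of donors and acceptors. Until this result, the only step beyond the scatter among the compounds shown came from a phenyl in place of hydrogen on an aromatic carbon of the furan ring, so a substituent had to be added for the number to move. Here nothing is added, and moving the attachment from furan-2-yl to furan-3-yl on the double-bonded chain carbon is enough to carry the number beyond the scatter, but no measurement at hand accounts for this difference.

The compounds shown leave open whether a phenyl on the furan-3-yl ring would lower the number as it does on the furan-2-yl ring of compound 3, since only the latter ring carries one here. They also leave open how a smaller or charged group, such as a methyl group, an amine or a carboxylic acid, would behave on the ring of compound 4.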